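A few compounds are considered here, and "the series" means these few. Any claim that something is new, unique, unknown or untested is made for them only; others in the source may bear on it.

Four compounds share one core and differ only in the group carried on a nitrogen on an aromatic ring. Compound 1 `O=C(NCc1ccc(F)cc1)c1nc(Br)c2cccnc2c1NCc1ccccc1` bears a benzyl group there, and in a functional assay on MCF7 cells (Homo sapiens) for cytotoxicity, read by MTT assay, with a stated time of 72 h (a lower number here means a stronger inhibitor, a higher number a weaker inhibitor), compound 1 gives "not determined" (no result reported). Compound 2 `NCCNc1c(C(=O)NCc2ccc(F)cc2)nc(Br)c2cccnc12` carries a short aminoalkyl chain, and in this assay compound 2 gives 6000 nM. Compound 3 `C[C@H](Nc1c(C(=O)NCc2ccc(F)cc2)nc(Br)c2cccnc12)c1ccccc1` carries a 1-phenylethyl group, and in this assay compound 3 gives "not determined" (no result reported). So compound 3 stands without a number, as does compound 1, and compound 2 is the only compound with a measured value.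

Compound 4 `NCCCCCCNc1c(C(=O)NCc2ccc(F)cc2)nc(Br)c2cccnc12` is the next compound, reached from compound 3 by the change (6-aminohexyl in place of 1-phenylethyl on a nitrogen on an aromatic ring). Among the compounds with values here, no step between measured compounds exists here, so no measured step size can be drawn on, and the direction from compound 3 cannot be stated. The expectation for compound 4 rests instead on compound 2, whose value of 6000 nM comes from a compound that also carries an aminoalkyl chain at the same nitrogen. Compound 4 is expected to give about 4000 nM in this assay, within 1200 nM to 15000 nM.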

Compound 4, half-maximal inhibitory concentration: 2000 nM
Beside the measured number, compound 4's estimate is 2.0-fold (0.30 log units) above it, within the range that was stated.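

Within the data shown here, the aminoalkyl chain on this nitrogen gives the first measured comparison at this position: in this assay the longer 6-aminohexyl chain goes with a stronger result (a 3.0-fold lower number from compound 2 to compound 4 (0.48 log units; beyond the scatter)). The step is modest but beyond the usual scatter, so chain length at this nitrogen does register in the read-out, although a single pair shows only a difference between two chains and not a trend. Nothing available here explains the difference.

The swap of 1-phenylethyl for 6-aminohexyl cannot be read, as compound 3 has no number, and the same holds for the benzyl group of compound 1. Also open, going by these compounds, is whether a 3-aminopropyl chain would fall between compound 2 and compound 4, and whether a longer chain or one ending in a carboxylic acid would continue the direction.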